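The source may hold more compounds than are shown below. What is called first, only, known or untested is meant among the compounds shown, and "the series" means these compounds.

Measured so far:
compound 1 `CC(C)(C)C[C@@H](O)C(=O)N1C[C@@H]2C[C@@H]2[C@H]1C(=O)NCc1cc(Cl)ccc1-n1cnnn1`: 25 10^-6 cm/s
compound 2 `CC(C)(C)C[C@@H](O)C(=O)N1OCC[C@H]1C(=O)NCc1cc(Cl)ccc1-n1cnnn1`: 25 10^-6 cm/s

Both values come from an ADME assay on Caco-2 cells (Homo sapiens) for permeability, read by LC-MS, in the apical to basolateral direction, with a stated time of 60 min, at pH 6.5; a lower number here means that the compound crosses the layer more slowly, a higher number that the compound crosses the layer faster. Compound 1 stands level with compound 2, the two values lying within the scatter of each other, although the cores differ.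

The next compound is compound 3 `O=C(NCc1cc(Cl)ccc1-n1cnnn1)[C@@H]1[C@H]2C[C@H]2CN1C(=O)[C@H](O)CC1CC1`, which keeps the core of compound 1. It carries cyclopropyl in place of tert-butyl on a saturated chain carbon, two bonds along the chain from a carbonyl carbon and an oxygen on a saturated carbon. Cut one bond further out, the same difference reads neopentyl to cyclopropylmethyl.

Within the data shown here, no measured pair isolates this change, so the data offer no direct precedent for its size. In this assay, a slight fall is expected, but not one beyond the scatter. The estimate amounts to an expected 1.4-fold lower number from compound 1 to compound 3 (0.14 log units; within the scatter). The expected value for compound 3 is 18 10^-6 cm/s, with an estimated range of 8 10^-6 cm/s to 32 10^-6 cm/s.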

Compound 3, apparent permeability: 3.4 10^-6 cm/s
Compound 3: the middle estimate sits 5.3-fold (0.72 log units) above what was measured; measured number outside the range, below it.
By their numbers in this assay, from the lowest: compound 3; then compounds 1 and 2 (each within the scatter of the next).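

Held on the core of compound 1, the place on a saturated chain carbon, two bonds along the chain from a carbonyl carbon and an oxygen on a saturated carbon, proves sensitive in this assay: cyclopropyl in place of tert-butyl gives a 7.4-fold lower number from compound 1 to compound 3 (0.87 log units; beyond the scatter). Among these compounds, compound 1 and compound 2 showed only that two different cores can stand level, whereas this step changes the chain end alone and lies beyond the scatter, even though neither group carries a hydrogen-bond donor, acceptor or net charge. Nothing measured in the series accounts for the size of this step.

As far as these compounds go, a single step cannot separate the entry of the ring from the shortening of the group, so it remains open whether an open-chain isopropyl or a larger cyclobutyl at the same place would stand nearer compound 1 or compound 3. From the compounds shown here alone, it also remains open whether cyclopropyl in place of tert-butyl on the core of compound 2 would give a step of similar size.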